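Swapping Methyl for Nitro on the Pendant Phenyl Ring

A few compounds are considered here, and "the series" means these few. Any claim that something is new, unique, unknown or untested is made for them only; others in the source may bear on it.

Measured compounds:
compound 1, `CC(c1ccc(-c2ccccc2)c(F)c1)c1nnc2n1N=C(c1ccccc1)CS2`: 6700 nM
compound 2, `Cc1ccc(C2=Nn3c(nnc3C(C)c3ccc(-c4ccccc4)c(F)c3)SC2)cc1`: 7200 nM

In a functional assay on Huh-7 cells (Homo sapiens) for inhibition, read by sulforhodamine B assay, with a stated time of 72 h (a lower number here means a stronger inhibitor, a higher number a weaker inhibitor), compound 1 gives 6700 nM, and compound 2 gives 7200 nM. Compound 2 holds the higher of the two numbers, but the step of a 1.1-fold higher number from compound 1 to compound 2 (0.03 log units; within the scatter) lies within the scatter, so the two compounds cannot be separated on these data.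

Compound 3, `CC(c1ccc(-c2ccccc2)c(F)c1)c1nnc2n1N=C(c1ccc([N+](=O)[O-])cc1)CS2`, has not yet been measured. It differs from compound 2 by nitro in place of methyl on an aromatic carbon; the nitro group sits on an aromatic carbon of a six-membered aromatic ring of carbon only, para to a large group. Going by the values given here, the single measured step, a 1.1-fold higher number from compound 1 to compound 2 (0.03 log units; within the scatter), concerns a different exchange, methyl for hydrogen, and stayed within the scatter. Among the compounds with values here, no measured step bears directly on putting a nitro group where a methyl group was, so the direction of any change is unknown.

Given the one flat step seen, compound 3 is expected to show no step beyond the scatter, with the estimate carrying a wide range.

Compound 3 is estimated at 7000 nM in this assay, between 2500 nM and 20000 nM.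

This expected estimate corresponds to the step of a 1.0-fold lower number from compound 2 to compound 3 (0.01 log units; within the scatter).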

Compound 3, half-maximal inhibitory concentration: 4300 nM
Estimate against measurement, compound 3: 1.6-fold (0.21 log units) above, within the range that was stated.
By their numbers in this assay, from the lowest: compounds 3, 1 and 2 (each within the scatter of the next).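

Putting nitro on this carbon of the pendant phenyl ring, with three heavy atoms and two hydrogen-bond acceptors where methyl had one heavy atom and none, leaves the result in this assay unresolved: going from 4-methylphenyl to 4-nitrophenyl gives a 1.7-fold lower number from compound 2 to compound 3 (0.22 log units; within the scatter) and the comparison with hydrogen at that carbon gives a 1.6-fold lower number from compound 1 to compound 3 (0.19 log units; within the scatter) so neither step can be read as a real change. Hydrogen, methyl and nitro therefore all sit within the scatter of one another at this position, which shows that even the largest of the three groups shown here does not separate from the other two, something the first pair, limited to hydrogen and methyl, could not show. No measurement at hand speaks to what lies behind this flat result.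

From the compounds shown here alone, whether an amine, a carboxylic acid or a longer chain on this same carbon would move the number beyond the scatter remains open. Going by these compounds, all three compounds also share the rest of the molecule, so how the number responds to a change anywhere else is untested by these compounds.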